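Replacing the sugar of compound 2 with cyclopentyl

The compounds below may be only part of what the source reports. "The series", "measured", "known", "first", "only" and "open" are said of these compounds alone.

Measured so far:
- compound 1 `Cc1ccccc1NC(=O)Nc1ccc(-n2cc(CCO)nn2)cc1`: 13000 nM
- compound 2 `CCCCc1cn(-c2ccc(NC(=O)Nc3cc(O[C@H]4O[C@@H](CO)[C@H](O)[C@@H]4O)ccc3C)cc2)nn1`: "not active" (no number reported)

In an assay on isolated protein for inhibition of ATP-dependent RNA helicase DDX3X (Homo sapiens), read by FRET, with stated times of 30 s and 40 min (on this read-out lower numbers stand for stronger inhibition and higher numbers for weaker inhibition), compound 1 gives 13000 nM. In this assay compound 2 is reported as "not active" (no number reported), with no number attached, so compound 2 stands below anything on the scale shown here and its position relative to compound 1 cannot be put in figures.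

Compound 3 `CCCCc1cn(-c2ccc(NC(=O)Nc3cc(OC4CCCC4)ccc3C)cc2)nn1` is the next point. Its change from compound 2 is cyclopentyl in place of 3,4-dihydroxy-5-(hydroxymethyl)oxolan-2-yl on an oxygen on an aromatic ring. Among the measured compounds shown here, no measured pair follows this kind of change, so the size of the step in this assay cannot be read from a precedent; with compound 2 reported without a number, a step toward a measurable value is expected, of uncertain size.

For compound 3 in this assay the expected value is 10000 nM, with a range from 2000 nM to 50000 nM, and a fair chance that only a limit is returned.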

Compound 3, half-maximal inhibitory concentration: 140 nM
For compound 3 the middle estimate is 71-fold (1.85 log units) above the measured one, and the stated range ends above it.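

In this assay, among the compounds shown here, compound 3 gives 140 nM and compound 2 has no number, so no step between them can be read. The compounds shown leave open how much of the gap belongs to the cyclopentyl ring itself. No measurement shown here speaks to a cause.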